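The source may hold more compounds than are shown below. What is called first, only, known or untested is meant among the compounds shown, and "the series" means these compounds.

Measured so far:
Compound 1 `CCNc1ccc2c(c1)OC(N)=C(C#N)C2c1cc(Br)c(OC)c(OC)c1`: 14000000 nM
Compound 2 `COc1cc(C2C(C#N)=C(N)Oc3cc(Br)ccc32)cc(Br)c1OC`: 140000000 nM

In a functional assay on T47D cells (Homo sapiens) for activation (a lower number here means that less compound is needed, a higher number that more compound is needed for the effect), compound 2 stands highest of the two numbers; compound 1 gives 14000000 nM as the nearest number. Compound 3 `CCOc1ccc2c(c1)OC(N)=C(C#N)C2c1cc(Br)c(OC)c(OC)c1` differs from compound 2 by ethoxy in place of bromo on an aromatic carbon. Within the data shown here, the single measured step bears on this change: a 10-fold higher number from compound 1 to compound 2 (1.00 log units; beyond the scatter), ethylamino against bromo at the same carbon. Ethoxy matches ethylamino in chain length rather than bromo, so the step is expected to run back down, roughly reversing that step: a 7.0-fold lower number from compound 2 to compound 3 (0.85 log units; beyond the scatter). Compound 3 is therefore estimated at 20000000 nM, with a range from 5000000 nM to 80000000 nM.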

Compound 3, half-maximal effective concentration: 64000000 nM
Beside the measured number, compound 3's estimate is 3.2-fold (0.51 log units) below it; the range from low to high includes it.
By their numbers in this assay, from the lowest: compound 1; then compound 3; then compound 2.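

In this assay, ethoxy at this aromatic carbon sits between the two earlier groups: a 2.2-fold lower number from compound 2 to compound 3 (0.34 log units; beyond the scatter), and a 4.6-fold higher number from compound 1 to compound 3 (0.66 log units; beyond the scatter). Ethoxy and ethylamino therefore do not read as equivalent here, as the second step lies beyond the scatter. The position now ranks three groups, with ethylamino lowest, then ethoxy, then bromo. Nothing available explains this order.

Open, from the compounds shown here alone, is where a free amine, a methoxy group or a longer alkoxy chain would fall at this carbon. Also open, going by these compounds, is whether the order holds when the bromo on the other aromatic ring is replaced.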